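The source may hold more compounds than are shown below. What is called first, only, known or untested is meant among the compounds shown, and "the series" means these compounds.

For the measured compounds named here, the three compounds measured so far share one core and differ only in a single group on it. Compound 1 `Cc1cccc(C(=O)Nc2ccc(C#N)cc2)c1O` carries a methyl group, compound 2 `N#Cc1ccc(NC(=O)c2ccc(-c3ccncc3)cc2O)cc1` carries a pyridin-4-yl group, and compound 3 `COc1ccc(C(=O)Nc2ccc(C#N)cc2)c(O)c1` carries a methoxy group. In a functional assay on KG-1 cells (Homo sapiens) for cytotoxicity, read by luminescence and CellTiter-Glo, with a stated time of 3 days (on this read-out lower numbers stand for stronger inhibition and higher numbers for weaker inhibition), compound 1 gives 8980 nM, compound 2 gives 8840 nM, and compound 3 gives 5430 nM. Compound 3 thus shows the lowest of the three numbers, yet its gaps to compound 2 and to compound 1 both fall within the scatter, so none of the three can be called more potent than another on these data.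

Compound 4 `N#Cc1ccc(NC(=O)c2ccccc2O)cc1` is the unmeasured member, and its difference from compound 3 is hydrogen in place of methoxy on an aromatic carbon. Going by the values given here, the only measured step that touches this same place is a 1.6-fold lower number from compound 2 to compound 3 (0.21 log units; within the scatter), in which one group was exchanged for another and the number hardly moved. That single comparison suggests the group at this place has little influence on the read-out, although removing it entirely has not been tested. For compound 4 the step of a 1.2-fold higher number from compound 3 to compound 4 (0.08 log units; within the scatter) is therefore expected to stay within the scatter. Compound 4 is estimated at 6500 nM, with a range from 2500 nM to 17000 nM.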

Compound 4, half-maximal inhibitory concentration: 5370 nM
Compound 4: the middle estimate sits 1.2-fold (0.08 log units) above what was measured, within the range that was stated.
By their numbers in this assay, from the lowest: compounds 4, 3, 2 and 1 (each within the scatter of the next).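

For the compounds shown here, with compound 4, this place on the ring is seen carrying only hydrogen for the first time: in this assay, taking away the methoxy group gives a 1.0-fold lower number from compound 3 to compound 4 (0.00 log units; within the scatter) and taking away the pyridin-4-yl group gives a 1.6-fold lower number from compound 2 to compound 4 (0.22 log units; within the scatter), so on these data hydrogen, methoxy and pyridin-4-yl at this place cannot be told apart. The methyl group of compound 1 sits on a different aromatic carbon, and exchanging it for hydrogen gives a 1.7-fold lower number from compound 1 to compound 4 (0.22 log units; within the scatter), so that place, too, shows no change that can be told from the scatter, and no group shown so far stands apart from the unsubstituted compound. No other measurement bears on this result.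

From the compounds shown here alone, it remains open whether a group of another kind at this place, such as an amine, a carboxylic acid or a longer chain, would move the number beyond the scatter. Going by these compounds, it also remains open how much the hydroxy group, the nitrile or the amide hydrogen counts for this read-out, as all four compounds keep them unchanged.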